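A few compounds are considered here, and "the series" means these few. Any claim that something is new, unique, unknown or untested is made for them only; others in the source may bear on it.

The measured compounds and their numbers:

Compound 1, `COc1cccc(CNCCCNc2ccnc3cc(Oc4ccc(Cl)cc4)ccc23)c1O` — in an ADME assay on HepG2 cells (Homo sapiens) for cytotoxicity, read by luminescence, CellTiter-Glo and ATP content, with a stated time of 72 h (on this read-out lower numbers stand for an effect already at smaller amounts and higher numbers for an effect only at larger amounts of compound), compound 1 gives 5700 nM.
Compound 2, `COc1cccc(CNCCCNc2ccnc3cc(Oc4ccc(F)cc4)ccc23)c1O` — compound 2 gives 11000 nM.
Compound 3, `COc1cccc(CNCCCNc2ccnc3cc(CCC(C)C)ccc23)c1O` — compound 3 gives 5390 nM.

Compound 3 has the lowest of the three numbers, but only the gap to compound 2 is beyond the scatter; compound 1 sits within the scatter of it. Compound 4, `COc1cccc(CNCCCNc2ccnc3cc(-c4ccccc4)ccc23)c1O`, has not been measured. It differs from compound 3 in one place: phenyl in place of isopentyl on an aromatic carbon.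

Among the compounds with values here, the steps that bear on this are those that changed the same aromatic carbon: a 1.1-fold lower number from compound 1 to compound 3 (0.02 log units; within the scatter) and a 2.0-fold lower number from compound 2 to compound 3 (0.31 log units; beyond the scatter), while a 1.9-fold higher number from compound 1 to compound 2 (0.29 log units; within the scatter) shows how little the substituent there has moved the read-out so far. None of these swaps a chain for a ring, so the comparison is indirect. Across all three compounds the numbers span barely a two-step scatter, which suggests that compound 4 will also land close to compound 3, with no step beyond the scatter expected, and the expected change is a 1.1-fold higher number from compound 3 to compound 4 (0.05 log units; within the scatter). For compound 4 the estimate is 6000 nM, with a range from 2500 nM to 15000 nM.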

Compound 4, half-maximal effective concentration: 3210 nM
For compound 4 the middle estimate is 1.9-fold (0.27 log units) above the measured one, and the stated range covers the measured number.
By their numbers in this assay, from the lowest: compounds 4, 3, 1 and 2 (each within the scatter of the next, the first and the last beyond it).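

Swapping the open isopentyl chain for a phenyl ring on this aromatic carbon gives, in this assay, a 1.7-fold lower number from compound 3 to compound 4 (0.23 log units; within the scatter), so a chain and a ring are not told apart here. Within the data shown here, removing the 4-chlorophenoxy group in favour of phenyl likewise gives a 1.8-fold lower number from compound 1 to compound 4 (0.25 log units; within the scatter), whereas the same swap for 4-fluorophenoxy gives a 3.4-fold lower number from compound 2 to compound 4 (0.53 log units; beyond the scatter), the largest step at this position so far and the only new one that clears the scatter. No measurement at hand accounts for these steps.

As far as these compounds go, the groups on this carbon so far are an all-carbon chain, phenyl and two halogen-bearing phenoxy groups, so it remains open whether an amine or a carboxylic acid there would move the number beyond the scatter from compound 4. From the compounds shown here alone, it is also open whether a chloro or fluoro on the phenyl of compound 4 would shift it.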